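A few compounds are considered here, and "the series" means these few. Any claim that something is new, unique, unknown or untested is made for them only; others in the source may bear on it.

Measured in a functional assay on BT-474 cells (Homo sapiens) for inhibition, read by fluorescence, with a stated time of 72 h; on this read-out higher numbers stand for weaker inhibition of growth and lower numbers for stronger inhibition of growth:

- compound 1 `CC(C)CCn1cnc2c(Nc3ccc(Cl)cc3)nc(N[C@H]3CC[C@H](N)CC3)nc21` gives 5100 nM
- compound 2 `CCCCn1cnc2c(NCc3cccc(Cl)c3)nc(N[C@H]3CC[C@H](N)CC3)nc21` gives 4700 nM
- compound 3 `CCCCn1cnc2c(Nc3cc(OC)cc(OC)c3)nc(N[C@H]3CC[C@H](N)CC3)nc21` gives 15600 nM

Of these three, compound 3 gives the highest number, and compound 1 and compound 2 both stand beyond the scatter from it. Compound 1 and compound 2 lie within the scatter of each other.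

The next compound, compound 4 `CCCCn1cnc2c(Nc3ccc(Cl)cc3)nc(N[C@H]3CC[C@H](N)CC3)nc21`, keeps the butyl chain of compound 3 and changes one group: 4-chlorophenyl in place of 3,5-dimethoxyphenyl on a nitrogen on an aromatic ring. Put simply, it has 4-chlorophenyl in place of 3,5-dimethoxyphenyl on a nitrogen on an aromatic ring.

Among the measured compounds shown here, one measured step bears on this place directly. It is a 3.3-fold higher number from compound 2 to compound 3 (0.52 log units; beyond the scatter), and it arrives at the same 3,5-dimethoxyphenyl group from 3-chlorobenzyl. The closest guide to the entering group is compound 1 at 5100 nM, which carries 4-chlorophenyl on a different chain. For the measured compounds named here, no measured pair isolates the effect of that chain, so this comparison remains indirect. A modest step toward stronger inhibition of growth is therefore expected, of about the size seen in the measured step. The expected change is a 2.8-fold lower number from compound 3 to compound 4 (0.45 log units; beyond the scatter). For compound 4 the estimated value is 5500 nM, with an expected range from 2300 nM to 13000 nM.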

Compound 4, concentration for 50% growth inhibition: 7300 nM
For compound 4 the middle estimate is 1.3-fold (0.12 log units) below the measured one; low and high end bracket the measured number.
By their numbers in this assay, from the lowest: compounds 2, 1 and 4 (each within the scatter of the next); then compound 3.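

With the butyl chain held constant, this assay gives a direct reading at this nitrogen: a 2.1-fold lower number from compound 3 to compound 4 (0.33 log units; beyond the scatter), so the step that took 3-chlorobenzyl to 3,5-dimethoxyphenyl is now matched by a step from 3,5-dimethoxyphenyl to 4-chlorophenyl, and 3,5-dimethoxyphenyl stands apart from both other groups. Among the compounds shown here, the comparison of the two remaining groups, a 1.6-fold higher number from compound 2 to compound 4 (0.19 log units; within the scatter), does not separate 4-chlorophenyl from 3-chlorobenzyl, and the exchange of methyl for hydrogen on the chain, a 1.4-fold higher number from compound 1 to compound 4 (0.16 log units; within the scatter), which no earlier pair isolated, leaves the two chains equally unresolved. No evidence in hand accounts for any of these differences.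

The compounds shown do not tell whether the higher number of compound 3 comes from having two methoxy groups or from the ring as a whole, which a single methoxy group on the phenyl ring could test. They also leave open how this nitrogen would respond to an amine or a carboxylic acid on the phenyl ring, and how the read-out would respond to a longer chain in place of butyl.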